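A few compounds are considered here, and "the series" means these few. Any claim that something is new, unique, unknown or untested is made for them only; others in the source may bear on it.

Measured so far in a functional assay on MCF7 cells (Homo sapiens) for inhibition, read by CCK-8 assay, with a stated time of 48 h; on this read-out lower numbers stand for stronger inhibition and higher numbers for weaker inhibition:
compound 1 `O=C(NC(=S)Nc1ccc(F)cc1)c1cn(-c2ccccc2)nc1-c1ccccc1` gives 6820 nM
compound 2 `O=C(NC(=S)Nc1ccc(F)cc1)c1cn(-c2ccccc2)nc1-c1ccc(F)cc1` gives 5610 nM
compound 3 `O=C(NC(=S)Nc1ccc(F)cc1)c1cn(-c2ccccc2)nc1-c1ccc(Cl)cc1` gives 5990 nM

On these three numbers compound 3 sits between the other two, its nearest neighbour being compound 2 and its furthest compound 1, and neither gap reaches beyond the scatter: the step of a 1.1-fold higher number from compound 2 to compound 3 (0.03 log units; within the scatter) and the step of a 1.1-fold lower number from compound 1 to compound 3 (0.06 log units; within the scatter) are both small, as is a 1.2-fold lower number from compound 1 to compound 2 (0.08 log units; within the scatter). The whole set so far spans less than the usual scatter, so no ordering among compound 1, compound 2 and compound 3 can be read from it.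

Compound 4 `Cc1ccc(-c2nn(-c3ccccc3)cc2C(=O)NC(=S)Nc2ccc(F)cc2)cc1` differs from compound 3 by methyl in place of chloro on an aromatic carbon. The measured steps that bear on this place are the three above, where hydrogen, fluoro and chloro were exchanged at the same aromatic carbon; none of them moved the number beyond the scatter. Within the data shown here, no measured step has methyl entering anywhere, so the new group itself is untested. On the evidence of the steps at this place, the step of a 1.0-fold higher number from compound 3 to compound 4 (0.00 log units; within the scatter) is expected to lie within the scatter, with no direction that can be called. Compound 4 is therefore expected to give 6000 nM in this assay, with a range from 3000 nM to 12000 nM.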

Compound 4, half-maximal inhibitory concentration: 6420 nM
Compound 4: the middle estimate sits 1.1-fold (0.03 log units) below what was measured; measured number inside the range.
By their numbers in this assay, from the lowest: compounds 2, 3, 4 and 1 (each within the scatter of the next).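

In this assay, among these compounds, methyl brings a carbon group to an aromatic carbon that held only hydrogen, fluoro or chloro in the earlier compounds, and none of its steps leaves the scatter: methyl for chloro gives a 1.1-fold higher number from compound 3 to compound 4 (0.03 log units; within the scatter), methyl for fluoro gives a 1.1-fold higher number from compound 2 to compound 4 (0.06 log units; within the scatter), and methyl for hydrogen gives a 1.1-fold lower number from compound 1 to compound 4 (0.03 log units; within the scatter). The change from 4-chlorophenyl to 4-methylphenyl therefore adds a fourth substituent state to the same level, so the insensitivity seen so far at this place is no longer confined to hydrogen and the two halogens, and the four compounds still allow no ordering. Nothing available explains this flat response at the position.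

Going by these compounds, it remains open whether an amine, a carboxylic acid, a methoxy group or a longer chain such as butyl on this aromatic carbon would move the number beyond the scatter, since the groups compared here are all single-atom substituents. The compounds shown also leave open whether changes elsewhere on the shared core, such as replacing the sulfur of the thiocarbonyl with oxygen, would matter more than changes at this place.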